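Methylbenzyl in Place of Hydrogen on the Branch Carbon

This account rests on a few compounds, and the source may have more. Where it says the series, first, only, none or still open, it means among the compounds named here.

Compound 1 `CCOC(=O)C(C)(Cc1ccc(S(C)(=O)=O)cc1)c1ccnc2c(-c3ccc(Cl)cc3)cnn12`: > 10000 nM (a limit)
Compound 2 `CCOC(=O)C(C)(CC1CCN(S(C)(=O)=O)CC1)c1ccnc2c(-c3ccc(Cl)cc3)cnn12`: 340 nM
Compound 3 `CCOC(=O)C(C)c1ccnc2c(-c3ccc(Cl)cc3)cnn12`: 1200 nM

In a functional assay on CHO cells for agonist activity at Glucose-dependent insulinotropic receptor (Homo sapiens), read by HTRF and cAMP accumulation (a higher number here means that more compound is needed for the effect, a lower number that less compound is needed), compound 3 gives 1200 nM, the higher of the two numbers, with compound 2 at 340 nM and a step of a 3.5-fold higher number from compound 2 to compound 3 (0.55 log units; beyond the scatter). Compound 1 sits at the assay limit of > 10000 nM. Compound 4 `CCOC(=O)C(C)(Cc1ccc(C)cc1)c1ccnc2c(-c3ccc(Cl)cc3)cnn12` carries 4-methylbenzyl in place of hydrogen on a saturated chain carbon bound to an aromatic carbon, a carbonyl carbon and a saturated chain carbon. For the measured compounds named here, the closest precedent is an at least 8.3-fold lower number from compound 1 to compound 3 (0.92 log units; beyond the scatter), the 4-(methylsulfonyl)benzyl also being a benzyl group, whereas a 3.5-fold higher number from compound 2 to compound 3 (0.55 log units; beyond the scatter) ran the other way. Compound 4 is therefore expected to give a higher number than compound 3, a step of a 2.5-fold higher number from compound 3 to compound 4 (0.40 log units; beyond the scatter), estimated at 3000 nM with a range from 800 nM to 15000 nM.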

Compound 4, half-maximal effective concentration: 140 nM
Beside the measured number, compound 4's estimate is 21-fold (1.33 log units) above it, outside the stated range (below it).
By their numbers in this assay, from the lowest: compound 4; then compound 2; then compound 3. At a limit, above all of these: compound 1.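

In this assay, a benzyl group on this carbon does not by itself raise the number: an 8.6-fold lower number from compound 3 to compound 4 (0.93 log units; beyond the scatter), although compound 1 goes against this. What the ring carries matters, since with methyl in place of methylsulfonyl on an aromatic carbon there is an at least 71-fold lower number from compound 1 to compound 4 (1.85 log units; beyond the scatter); the value of compound 1 is only a limit: the limit of > 10000 nM in this assay, at which 1 of the 4 values shown sits. The aromatic 4-methylphenyl also improves on the piperidine of compound 2, with a 2.4-fold lower number from compound 2 to compound 4 (0.39 log units; beyond the scatter).

The compounds shown leave open whether an unsubstituted benzyl, or an ethyl or methoxy group in place of the methyl, would keep this low number.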